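This account rests on a few compounds, and the source may have more. Where it says the series, first, only, none or still open, it means among the compounds named here.

Going by the values given here, compound 2 `Cc1ccccc1CNC(=O)C(=O)N[C@@H](C)C(=O)N[C@@H](CC(=O)O)C(=O)COc1c(F)c(F)cc(F)c1F` gives 52 nM in a functional assay on Jurkat cells (Homo sapiens) (on this read-out lower numbers stand for stronger inhibition and higher numbers for weaker inhibition), the higher of the two numbers measured so far; its nearest neighbour, compound 1 `C[C@H](NC(=O)C(=O)NCC1(c2ccccc2)CC1)C(=O)N[C@@H](CC(=O)O)C(=O)COc1c(F)c(F)cc(F)c1F`, gives 27 nM, and the step of a 1.9-fold higher number from compound 1 to compound 2 (0.28 log units; within the scatter) lies within the scatter, so the two compounds cannot be told apart on these data. Compound 3 `C[C@H](NC(=O)C(=O)NCc1ccccc1F)C(=O)N[C@@H](CC(=O)O)C(=O)COc1c(F)c(F)cc(F)c1F` differs from compound 2 in a single place: fluoro in place of methyl on an aromatic carbon. Among the compounds with values here, no measured step bears on this change. Within the data shown here, the only step recorded exchanges the whole group on the saturated chain carbon bound to the amide-type nitrogen rather than a substituent on the aromatic ring, and it stayed within the scatter, so it offers no direction for the present exchange. Nothing in the numbers therefore points to a step beyond the scatter in this assay, in either direction. Compound 3 is accordingly expected to give 50 nM, with a range from 20 nM to 130 nM. The expected step of a 1.0-fold lower number from compound 2 to compound 3 (0.02 log units; within the scatter) is set near zero, and the range is kept wide on both sides to reflect the absence of any step that speaks to this change.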

Compound 3, half-maximal inhibitory concentration: 207 nM
Compound 3: middle estimate off by 4.1-fold (0.62 log units), on the low side; measured number outside the range, above it.
By their numbers in this assay, from the lowest: compounds 1 and 2 (each within the scatter of the next); then compound 3.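

In this assay, the step between compound 1 and compound 2 stayed within the scatter, whereas fluoro in place of methyl on an aromatic carbon, ortho to a large group, gives a 4.0-fold higher number from compound 2 to compound 3 (0.60 log units; beyond the scatter), which lies beyond it. This shows that the number is sensitive to which single atom is attached at this place on the ring, a sensitivity the earlier pair could not reveal. The exchange of 1-phenylcyclopropyl for 2-fluorophenyl also gives a 7.7-fold higher number from compound 1 to compound 3 (0.88 log units; beyond the scatter), beyond the scatter, whereas 2-methylphenyl in the same exchange could not be told apart from 1-phenylcyclopropyl, and no available evidence accounts for the difference.

A single pair cannot show whether the higher number follows from the departure of methyl or from the arrival of fluoro, and a plain hydrogen, a chlorine atom or a methoxy group on the same aromatic carbon would separate these two readings. From the compounds shown here alone, it also remains open whether the same exchange would give a step of similar size in a compound carrying an ethyl group in place of the methyl on the shared core.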